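The source may report more compounds than this note shows. Statements on the series, on what has been measured and on what is new or still open speak of the compounds shown alone.

Of the compounds shown here, three built on a shared core have been measured in a functional assay on HEK293 cells for agonist activity at D(4) dopamine receptor (Homo sapiens), read by FLIPR; a lower number here means a smaller maximal response, a higher number a larger maximal response. Compound 1 `O=C(CN1CCC(c2cccc[n+]2[O-])CC1)NC1CCCCC1` gives 58%. Compound 2 `O=C(CN1CCC(c2cccc[n+]2[O-])CC1)Nc1cccc(Cl)c1Cl` gives 66%, and compound 3 `Cc1cc(Br)ccc1NC(=O)CN1CCC(c2cccc[n+]2[O-])CC1` gives 61%. On these numbers compound 3 stands second highest of the three, with compound 1 nearest and compound 2 furthest, both of them within the scatter of it. Compound 4 `O=C(CN1CCC(c2cccc[n+]2[O-])CC1)Nc1ccc(F)cc1` has not yet been measured in this assay. Its change from compound 3 is 4-fluorophenyl in place of 4-bromo-2-methylphenyl on an amide-type nitrogen. Going by the values given here, the steps that bear on this change all swap the group on the amide-type nitrogen: a number 8 percentage points higher from compound 1 to compound 2 (within the scatter), a number 3 percentage points higher from compound 1 to compound 3 (within the scatter) and a number 5 percentage points lower from compound 2 to compound 3 (within the scatter). None of them moved the maximal response beyond the scatter, so the expected step in this assay is a number 1 percentage points lower from compound 3 to compound 4 (within the scatter), nothing beyond the scatter. Compound 4 is therefore estimated at 60%, with a range from 48% to 72%.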

Compound 4, largest response reached (reported as efficacy), in percent of the reference or control that the assay uses: 71%
Estimate against measurement, compound 4: 11 percentage points below, and the stated range covers the measured number.
By their numbers in this assay, from the lowest: compounds 1, 3, 2 and 4 (each within the scatter of the next, the first and the last beyond it).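

In this assay, a change of the group on the amide-type nitrogen now gives a step beyond the scatter, a number 13 percentage points higher from compound 1 to compound 4 (beyond the scatter), with 4-fluorophenyl in place of cyclohexyl. The other two new steps, a number 10 percentage points higher from compound 3 to compound 4 (within the scatter) and a number 5 percentage points higher from compound 2 to compound 4 (within the scatter), stay within the scatter, so compound 4 separates only from compound 1 and not from the two compounds with a substituted phenyl carrying other halogens. This position can therefore shift the maximal response measurably, though among these four compounds only this one pair shows it.

Going by these compounds, it remains open how an unsubstituted phenyl, a 4-methoxyphenyl or a benzyl group on the amide-type nitrogen would compare with the 4-fluorophenyl of compound 4. No supporting data are available to explain the step from cyclohexyl to 4-fluorophenyl.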